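This account rests on a few compounds, and the source may have more. Where it says the series, first, only, none or still open, it means among the compounds named here.

Compound 1 `O=C1/C(=C/c2cccc([N+](=O)[O-])c2)CN(S(=O)(=O)c2ccc(F)cc2)C/C1=C\c1cccc([N+](=O)[O-])c1`: 3980 nM
Compound 2 `N#Cc1ccc(/C=C2\CN(S(=O)(=O)c3ccc(F)cc3)C/C(=C\c3ccc(C#N)cc3)C2=O)cc1`: 20100 nM
Compound 3 `CC(=O)Nc1ccc(S(=O)(=O)N2C/C(=C\c3ccccc3F)C(=O)/C(=C/c3ccccc3F)C2)cc1`: 7490 nM

All three values come from a functional assay on SMMC-7721 cells (Homo sapiens) for cytotoxicity, read by MTT assay, with a stated time of 24 h; on this read-out lower numbers stand for stronger inhibition and higher numbers for weaker inhibition. Compound 2 has the highest number of the three, beyond the scatter of both compound 3 and compound 1. Compound 4 `CC(=O)Nc1ccc(S(=O)(=O)N2C/C(=C\c3ccc(C#N)cc3)C(=O)/C(=C/c3ccc(C#N)cc3)C2)cc1` departs from compound 2 by acetamido in place of fluoro on an aromatic carbon, with acetamido in place of fluoro on an aromatic carbon. Among the compounds with values here, no measured pair isolates this change. Compound 3 also carries the acetamido group and gives 7490 nM, a lower number than compound 2, but its other groups differ too. A small move to a lower number is therefore expected, possibly within the scatter. The estimated step is a 1.7-fold lower number from compound 2 to compound 4 (0.22 log units; within the scatter). For compound 4 the expected value is 12000 nM, with an estimated range of 5000 nM to 28000 nM.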

Compound 4, half-maximal inhibitory concentration: 7120 nM
Compound 4: middle estimate off by 1.7-fold (0.23 log units), on the high side; the measured number falls inside the stated range.
By their numbers in this assay, from the lowest: compounds 1, 4 and 3 (each within the scatter of the next); then compound 2.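

In this assay, replacing 4-fluorophenyl with 4-acetamidophenyl while the rest of the molecule stays constant gives a 2.8-fold lower number from compound 2 to compound 4 (0.45 log units; beyond the scatter) as a modest change. Within the data shown here, this is the only isolated reading of the change at this aromatic carbon. The other groups of compound 3 also differ, so compound 3 does not provide such a reading. No available measurement explains the shift.

Going by these compounds, whether an amine or a carboxylic acid at this place would give a lower or higher number remains open. Also open, on these data alone, is whether the step recurs with the other arms carried by compound 1 and compound 3.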